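Propyl to isopropyl on the acyl carbonyl of compound 2

A few compounds are considered here, and "the series" means these few. Any claim that something is new, unique, unknown or untested is made for them only; others in the source may bear on it.

For the measured compounds named here, compound 2 `CCCC(=O)c1ccc(OCCCCOc2cccc(C(=O)O)c2C)c(C)c1O` carries the only number in this set: in an assay on HEK293 cells for positive allosteric modulation of metabotropic glutamate receptor 2 (Rattus norvegicus), read by thallium flux, with a stated time of 2.5 min (on this read-out higher numbers stand for an effect only at larger amounts of compound and lower numbers for an effect already at smaller amounts), compound 2 gives 52 nM. Compound 1 `COC(=O)c1ccc(OCCCCOc2ccc(C(=O)CC3CCCC3)c(O)c2C)cc1` has no number in this assay, where compound 1 stands as "not determined" (no result reported), so nothing can be said about how it compares. Compound 3 `Cc1c(OCCCCOc2ccc(C(=O)C(C)C)c(O)c2C)cccc1C(=O)O` differs from compound 2 in one place, (isopropyl in place of propyl on a carbonyl carbon), isopropyl in place of propyl on a carbonyl carbon whose other neighbour is an aromatic carbon. Going by the values given here, no measured pair in this set shows this change, so no step size is known from data. The two compounds have the same atoms, joined differently, with no change in ring count, donors, acceptors or charge, so the expected step of a 1.3-fold higher number from compound 2 to compound 3 (0.13 log units; within the scatter) is small, probably within the scatter, with no firm direction. Compound 3 is therefore estimated at about 70 nM, with a range from 25 nM to 200 nM.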

Compound 3, half-maximal effective concentration: 149 nM
Compound 3: middle estimate off by 2.1-fold (0.33 log units), on the low side; low and high end bracket the measured number.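

In this assay, for the compounds shown here, isopropyl in place of propyl on a carbonyl carbon gives a 2.9-fold higher number from compound 2 to compound 3 (0.46 log units; beyond the scatter), the first measured step at this position. The two compounds hold the same atoms, so a rearrangement of the acyl chain alone, with no change in ring count, donors, acceptors or charge, is enough to move the number modestly beyond the scatter, while compound 3 still gives 149 nM. No data here bear on the origin of this step.

Going by these compounds alone, one step cannot show whether the number follows the shape of the chain at this carbonyl or only this particular pair. As far as these compounds go, how a longer chain such as butyl, or a cyclopropyl group, would read at this place stays open, and compound 1 offers no comparison with its "not determined" (no result reported).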